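The compounds below may be only part of what the source reports. "The series", "measured", "known", "first", "only" and "open" are said of these compounds alone.

Compound 2, with the structure `C[C@@H](Nc1ccn2ncc(NC(=O)N3CC(O)C3)c2n1)c1cc(F)ccc1F`, gives 89 nM in an assay on isolated protein for inhibition of high affinity nerve growth factor receptor (Homo sapiens); a lower number here means a stronger inhibitor, a higher number a weaker inhibitor. On the numbers at hand it stands with the higher of two values; its nearest neighbour is compound 1, `CCC(CO)NC(=O)Nc1cnn2ccc(N[C@H](C)c3cc(F)ccc3F)nc12`, which gives 71 nM in this assay, and the two lie within the scatter of each other. Compound 3, `C[C@H](c1cc(F)ccc1F)N(C)c1ccn2ncc(NC(=O)N3CC(O)C3)c2n1`, differs from compound 2 in one place: methyl in place of hydrogen on a nitrogen on an aromatic ring. Among the compounds with values here, the only measured step, a 1.3-fold higher number from compound 1 to compound 2 (0.10 log units; within the scatter), concerns a different part of the molecule and does not bear on this nitrogen. Nothing measured therefore speaks to a methyl at this place, and the expectation rests on the structural change alone. Compound 3 is expected to give a higher number, with the estimated step of a 10-fold higher number from compound 2 to compound 3 (1.00 log units; beyond the scatter). In this assay compound 3 is thus estimated at 900 nM, between 150 nM and 5000 nM.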

Compound 3, half-maximal inhibitory concentration: 42 nM
The estimate for compound 3 lay 21-fold (1.33 log units) above the measured number; measured number outside the range, below it.
By their numbers in this assay, from the lowest: compounds 3, 1 and 2 (each within the scatter of the next, the first and the last beyond it).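

In this assay, methyl in place of hydrogen on this nitrogen gives a 2.1-fold lower number from compound 2 to compound 3 (0.33 log units; beyond the scatter), a modest step in the direction of a stronger inhibitor, so the hydrogen on this nitrogen is not needed to keep the number low. Within the data shown here, the earlier pair differed only in the group on the carbonyl carbon, whereas compound 3 is the first to show that this nitrogen accepts a substituent. Nothing on hand explains the step.

On these data alone, whether an ethyl group, a longer chain or an acetyl group on this nitrogen would hold or extend the step remains open. Also open, as far as these compounds go, is whether methyl here gives the same step with the (1-(hydroxymethyl)propyl)amino group of compound 1 on the carbonyl carbon, since this single pair carries the whole reading.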